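The compounds below may be only part of what the source reports. "The series", "measured", "known", "first", "only" and "open" are said of these compounds alone.

Three compounds built on the same core have been examined in an assay on HL-60 cells for agonist activity at N-formyl peptide receptor 3 (Homo sapiens), read by calcium flux; on this read-out higher numbers stand for an effect only at larger amounts of compound and lower numbers for an effect already at smaller amounts. Compound 1 `Cc1cc(Cc2ccccc2)c(=O)n(CC(=O)Nc2ccc(Br)cc2)n1` is the simplest of them; in this assay compound 1 gives > 50000 nM, which is a limit of the assay and not a number. Compound 2 `Cc1cc(Cc2cccc(F)c2)c(=O)n(CC(=O)Nc2ccc(Br)cc2)n1` carries a fluoro in place of a hydrogen on an aromatic carbon; in this assay compound 2 gives > 50000 nM, again a limit. Compound 3 `Cc1cc(Cc2cccc3ccccc23)c(=O)n(CC(=O)Nc2ccc(Br)cc2)n1` carries a naphthalen-1-yl in place of the phenyl on a saturated chain carbon bound to an aromatic carbon; in this assay compound 3 gives > 50000 nM, also a limit. Compound 3 thus stands where every value shown stands, because all three sit at the limit of > 50000 nM in this assay, at which 3 of the 3 values shown sit. For that reason the steps a step that the two limits leave unreadable from compound 1 to compound 2, a step that the two limits leave unreadable from compound 1 to compound 3 and a step that the two limits leave unreadable from compound 2 to compound 3 cannot be read in size or direction. Compound 4 `Cc1cc(Cc2cccnc2)c(=O)n(CC(=O)Nc2ccc(Br)cc2)n1` differs from compound 3 by pyridin-3-yl in place of naphthalen-1-yl on a saturated chain carbon bound to an aromatic carbon. Going by the values given here, no measured step gives a readable size for a change of this kind, so nothing suggests the value will leave the limit. The expected step is a number no higher from compound 3 to compound 4 (the limit leaves the size open), most likely ending again at a limit. Compound 4 is estimated to give 50000 nM in this assay, within 20000 nM to 150000 nM.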

Compound 4, half-maximal effective concentration: > 50000 nM
Compound 4: no number, only a limit; the forecaster's own chance of this, stated with the estimate: 85%; the middle value sits exactly at the limit.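

Compound 4 also ends at a limit, so the steps to it from compound 1, compound 2 and compound 3 cannot be read in size or direction: the limit of > 50000 nM in this assay, at which 4 of the 4 values shown sit. On these data alone, what stays open is whether, in this assay, any other group at this place on the shared core would give a real number instead of a limit.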